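This account rests on a few compounds, and the source may have more. Where it says the series, first, only, none or still open, it means among the compounds named here.

Measured compounds:
compound 1 `CNc1nccc(N2CC[C@H](NC(=O)Nc3cccc(C#N)c3)C2)n1`, with 91.5%
compound 2 `O=C(Nc1ccc(Cl)c(C(F)(F)F)c1)N[C@H]1CCN(c2ccnc(NC3CC3)n2)C1`, with 99.9%

In an ADME assay on a cell-free system (plasma, Mus musculus) for protein binding, compound 1 gives 91.5%, which leaves the largest unbound fraction of the two measured compounds. Compound 2 gives 99.9%, a far smaller unbound fraction, and the gap between compound 1 and compound 2 lies beyond the usual scatter of this assay. Compound 3 `CNc1nccc(N2CC[C@H](NC(=O)Nc3cccc(OC)c3)C2)n1` is not yet measured. It differs from compound 1 in one place: methoxy in place of cyano on an aromatic carbon. Among the measured compounds shown here, no pair of measured compounds differs in just this way, so there is no measured step to lean on. A modest shift toward more binding seems the most likely outcome, and the expected step from compound 1 to compound 3 is a 1.4-fold lower unbound fraction from compound 1 to compound 3 (0.15 log units; within the scatter), which would stay within the usual scatter. The value of compound 3 in this assay is therefore estimated at 94%, with a range from 88% to 98%.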

Compound 3, plasma protein binding: 91.6%
Compound 3: the middle estimate sits 1.4-fold (0.15 log units) (unbound fraction) below what was measured; the measured number falls inside the stated range.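

In this assay the exchange of 3-cyanophenyl for 3-methoxyphenyl gives a 1.0-fold lower unbound fraction from compound 1 to compound 3 (0.01 log units; within the scatter) and so shows that, on this aromatic carbon meta to a large group, methoxy and cyano cannot be told apart by this read-out. Among the compounds shown here, this is the first measured step in which only one place changes, and it gives a direct reading at this position: these two groups, each with the same count of heavy atoms, leave binding to plasma protein within the scatter. Nothing available explains why the two groups read alike here.

On these data alone, whether the same holds for other groups at this place, such as an amine, a carboxylic acid or a longer alkoxy chain, remains open. Also open, as far as these compounds go, is whether this exchange would read the same with a different group on the shared core.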